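Swapping chloro for methyl on the shared core

The source may report more compounds than this note shows. Statements on the series, on what has been measured and on what is new or still open speak of the compounds shown alone.

Going by the values given here, in a functional assay on ASPC1 cells (Homo sapiens) for antiproliferative activity, read by sulforhodamine B assay, with a stated time of 48 h (a higher number here means a weaker inhibitor, a lower number a stronger inhibitor), compound 3 `CO/N=C1/C(=O)N(CCCCCCC(=O)NO)c2ccc(Cl)cc21` gives 490 nM, the lowest of the three numbers so far. Compound 2 `CO/N=C1/C(=O)N(CCCCCCC(=O)NO)c2ccccc21` gives 1220 nM, and compound 1 `O=C(CCCCCCN1C(=O)/C(=N\O)c2cc(Cl)ccc21)NO` gives 1860 nM. Compound 4 `CO/N=C1/C(=O)N(CCCCCCC(=O)NO)c2ccc(C)cc21` carries methyl in place of chloro on an aromatic carbon. Among the compounds with values here, no measured compound carries this methyl, so the evidence is indirect. Within the data shown here, the one measured step that bears on it is a 2.5-fold lower number from compound 2 to compound 3 (0.40 log units; beyond the scatter), a modest change with chloro in place of hydrogen. Part of that step may be given back, so a small move toward a higher number is expected in this assay. The estimated step is a 1.5-fold higher number from compound 3 to compound 4 (0.17 log units; within the scatter). For compound 4 the estimate is 720 nM, with an expected range of 300 nM to 1600 nM.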

Compound 4, half-maximal inhibitory concentration: 5480 nM
Compound 4: middle estimate off by 7.6-fold (0.88 log units), on the low side; measured number outside the range, above it.
By their numbers in this assay, from the lowest: compound 3; then compounds 2 and 1 (each within the scatter of the next); then compound 4.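

In this assay, methyl in place of chloro gives an 11-fold higher number from compound 3 to compound 4 (1.05 log units; beyond the scatter), so two groups of one heavy atom each, neither a hydrogen-bond donor nor acceptor, are far from interchangeable at this position. Methyl in place of hydrogen gives a 4.5-fold higher number from compound 2 to compound 4 (0.65 log units; beyond the scatter), whereas chloro lowered the number, so this position can move the number in either direction. Nothing available here explains the gap between chloro and methyl. Still open, as far as these compounds go, is how a methoxy group, a fluorine or an amine would behave at this position, and whether chloro, hydrogen and methyl keep the same order on the core of compound 1.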